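This account rests on a few compounds, and the source may have more. Where it says the series, first, only, none or still open, it means among the compounds named here.

Among the compounds with values here, in an ADME assay on microsomes from liver (Rattus norvegicus) for metabolic stability, read by LC-MS, with a stated time of 1 h, at 37 degrees C, tested at 4 uM (a higher number here means that more of the compound is left, a lower number that less of the compound is left), three compounds have numbers so far. Compound 1 `Cn1sc2cc(OCc3cccc(-c4ccc(Cl)c(C(=O)O)c4)c3)ccc2c1=O` gives 84% and compound 2 `O=C(O)c1cc(-c2cccc(COc3ccc4c(=O)n(CC5CC5)sc4c3)c2)ccc1Cl` gives 75%, two values within the scatter of each other. Compound 3 `CN(C)C(=O)c1cc(-c2cccc(COc3ccc4c(=O)n(C5CCCC5)sc4c3)c2)ccc1Cl` gives 92%, which lies beyond the scatter above the value of compound 2.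

Compound 4 `O=C(O)c1cc(-c2cccc(COc3ccc4c(=O)n(C5CCC5)sc4c3)c2)ccc1Cl` has not yet been measured. It has the same atoms as compound 2, joined differently: cyclobutyl in place of cyclopropylmethyl on an aromatic nitrogen. In words, cyclobutyl takes the place of cyclopropylmethyl on an aromatic nitrogen.

Within the data shown here, only one measured step changes the group at this place and nothing else: a number 9 percentage points lower from compound 1 to compound 2 (within the scatter). Compound 3 differs from compound 2 in more than one place, so it offers no clean comparison. Among the measured compounds shown here, with the step to compound 2 as the only guide, a number 9 percentage points lower from compound 1 to compound 2 (within the scatter), no change beyond the scatter is expected in this assay, and the data suggest no firm direction. The expected step is small, a number 3 percentage points higher from compound 2 to compound 4 (within the scatter). For compound 4 the estimate is 78%, with an expected range from 65% to 91%.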

Compound 4, percent of the compound remaining: 67%
Compound 4: the middle estimate sits 11 percentage points above what was measured; the range from low to high includes it.
By their numbers in this assay, from the lowest: compounds 4, 2, 1 and 3 (each within the scatter of the next, the first and the last beyond it).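

In this assay, cyclobutyl in place of cyclopropylmethyl on the aromatic nitrogen gives a number 8 percentage points lower from compound 2 to compound 4 (within the scatter) and so, for these two groups built from the same atoms joined differently, the way the atoms are joined makes no readable difference. Cyclobutyl in place of methyl at the same nitrogen gives a number 17 percentage points lower from compound 1 to compound 4 (beyond the scatter) and is the first clean step at this position to lie beyond the scatter, which shows that the group here can matter, if only modestly. No measurement at hand explains this step.

On these data alone, compound 3 carries cyclopentyl at this nitrogen but also a dimethyl amide instead of the carboxylic acid, so the effect of that larger ring alone stays unknown. As far as these compounds go, whether an open butyl chain or a ring-bearing amine at this nitrogen would behave like cyclobutyl also remains open.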